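This account rests on a few compounds, and the source may have more. Where it says the series, first, only, none or still open, it means among the compounds named here.

Measured so far:
- compound 1, `CCc1ccc(N(CC(C)C)S(=O)(=O)c2ccc3c(c2)C(=O)CC(C2CCNCC2)O3)cc1`: 2.21
- compound 2, `CCS(=O)(=O)c1ccc(CNS(=O)(=O)c2ccc3c(c2)C(=O)CC(C2CCOCC2)O3)nc1`: 0.32
- compound 3, `CC(C)CN(c1ccc(N(C)C)cc1)S(=O)(=O)c1ccc2c(c1)C(=O)CC(C1CCOCC1)O2`: 3.6

In a physicochemical assay for lipophilicity, at pH 7.4 (on this read-out higher numbers stand for higher lipophilicity and lower numbers for lower lipophilicity), compound 3 stands highest of the three numbers. The nearest of the others is compound 1, whose value in this assay is lower by a gap beyond the scatter, and the furthest is compound 2, lower still by a gap well beyond the scatter. No pair among these three differs in only one place, so the numbers give the spread of the series but no single-change step to lean on.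

The next compound, compound 4, `CC(C)CN(c1ccc(C#N)cc1)S(=O)(=O)c1ccc2c(c1)C(=O)CC(C1CCOCC1)O2`, is the pair to compound 3: cyano in place of dimethylamino on an aromatic carbon

With no measured step of this kind in hand, the expectation rests on the change alone. A downward shift in this assay is expected, of moderate size and beyond the scatter, giving an estimated step of a number 0.75 log units lower from compound 3 to compound 4 (beyond the scatter). Compound 4 is therefore estimated at 2.85 in this assay, with a range from 2.3 to 3.4, which would place it still above compound 1 and well above compound 2. The measured value will show whether the step is of that size.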

Compound 4, distribution coefficient: 3.16
The estimate for compound 4 lay 0.31 log units below the measured number, and the stated range covers the measured number.
By their numbers in this assay, from the lowest: compound 2; then compound 1; then compound 4; then compound 3.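

In this assay the series now has its first single-change step: on an aromatic carbon of a six-membered aromatic ring of carbon only, para to a large group, cyano in place of dimethylamino gives a number 0.44 log units lower from compound 3 to compound 4 (beyond the scatter) and this modest shift lies beyond the scatter. The read-out at this position therefore responds to the exchange of 4-(dimethylamino)phenyl to 4-cyanophenyl, even though the two groups match in carrying no hydrogen-bond donors, one hydrogen-bond acceptor and no net charge, and differ in heavy atoms by only a small count. Nothing measured on these compounds accounts for the size of this step.

One step at one position does not show how a methoxy group, a chlorine atom, a carboxylic acid or a longer alkyl chain in the same place would read in this assay. It also leaves open whether cyano in place of dimethylamino would give a step of similar size on the core of compound 1, or with a different group on the sulfonamide nitrogen.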